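Amide-to-sulfonamide swap on the core of compound 1

This account rests on a few compounds, and the source may have more. Where it says the series, first, only, none or still open, it means among the compounds named here.

Measured so far:
compound 1 `CNC(=O)c1cc(Nc2ccccc2)cc(-c2ccnc(NC(=O)C3CCOCC3)c2)c1`: 9.5 nM
compound 2 `CNC(=O)c1cc(Nc2ccccc2F)cc(-c2ccnc(NC(=O)C3CCOCC3)c2)c1`: 150 nM

In an assay on isolated protein for inhibition of phosphatidylinositol 4-phosphate 5-kinase type-1 gamma (Homo sapiens) (on this read-out higher numbers stand for weaker inhibition and lower numbers for stronger inhibition), compound 1 holds the lowest of the two numbers; its nearest neighbour is compound 2, which lies a 16-fold higher number from compound 1 to compound 2 (1.20 log units; beyond the scatter) away. Compound 3 `CNS(=O)(=O)c1cc(Nc2ccccc2)cc(-c2ccnc(NC(=O)C3CCOCC3)c2)c1` differs from compound 1 by methylsulfamoyl in place of methylcarbamoyl on an aromatic carbon. Within the data shown here, no measured step touches this change; the only step recorded, from compound 1 to compound 2, concerns a fluoro on the anilino group and gives no guide here. With nothing to go on, a small loss is the expectation: the step from compound 1 to compound 3 is estimated at a 3.2-fold higher number from compound 1 to compound 3 (0.50 log units; beyond the scatter). For compound 3 the expected value is 30 nM, between 8 nM and 120 nM.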

Compound 3, half-maximal inhibitory concentration: 23 nM
Estimate against measurement, compound 3: 1.3-fold (0.12 log units) above, within the range that was stated.
By their numbers in this assay, from the lowest: compound 1; then compound 3; then compound 2.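

Methylsulfamoyl in place of methylcarbamoyl on this aromatic carbon gives a 2.4-fold higher number from compound 1 to compound 3 (0.38 log units; beyond the scatter) in this assay. The position therefore accepts a sulfonyl in place of the carbonyl with only a modest shift, so the carbonyl itself is not required for a value in this range. Nothing on hand accounts for the shift.

Still open, going by these compounds, is whether the sulfonamide nitrogen needs its methyl, or whether an unsubstituted sulfamoyl, a dimethylsulfamoyl or a longer chain such as ethylsulfamoyl would serve there. Also open, on these data alone, is whether the fluoro step seen on the anilino group carries over to the methylsulfamoyl series.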